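A Methoxy Added to Compound 1

The source may report more compounds than this note shows. Statements on the series, on what has been measured and on what is new or still open speak of the compounds shown alone.

In a functional assay on A-427 cells (Homo sapiens) for cytotoxicity, read by colorimetric assay and MTT assay (a higher number here means a weaker inhibitor, a lower number a stronger inhibitor), compound 1 (`COc1cccc2cc(-c3ccccc3)c(O)nc12`) gives 10000 nM and compound 2 (`COc1ccc2cc(-c3ccccc3)c(O)nc2c1`) gives 10000 nM so the two stand level within the scatter. Compound 3 (`COc1ccc(-c2cc3cccc(OC)c3nc2O)cc1`) departs from compound 1 by a single change (methoxy in place of hydrogen on an aromatic carbon) in which methoxy stands in place of hydrogen on an aromatic carbon of a six-membered aromatic ring of carbon only, para to a large group. Within the data shown here, no measured pair shows what such a change does, so the expectation is a cautious one. No step beyond the scatter is expected in this assay. Among the measured compounds shown here, the only guide is compound 1 at 10000 nM alongside compound 2 at 10000 nM in the same place. The estimated move is a 1.1-fold lower number from compound 1 to compound 3 (0.05 log units; within the scatter) and it is expected to stay within the scatter. For compound 3 the estimated value is 9000 nM with a range of 3500 nM to 20000 nM expected.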

Compound 3, half-maximal inhibitory concentration: 10000 nM
Beside the measured number, compound 3's estimate is 1.1-fold (0.05 log units) below it, within the range that was stated.
By their numbers in this assay, from the lowest: compounds 1, 2 and 3 (each within the scatter of the next).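

In this assay, putting methoxy in place of hydrogen on an aromatic carbon of the six-membered aromatic ring of carbon only, para to a large group, gives no change at the digits printed from compound 1 to compound 3 (within the scatter). Among these compounds, this is the first step that can be read as a single change, and it shows that this position accepts methoxy with no visible shift in the number. Nothing available explains why the number holds.

Going by these compounds, whether an amine, a carboxylic acid or a longer chain on the same aromatic carbon would shift the number remains open. So does whether methoxy would give the same result at another place on that ring.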